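Replacing morpholin-4-yl on a sulfonyl sulfur

The source may hold more compounds than are shown below. What is called first, only, known or untested is meant among the compounds shown, and "the series" means these compounds.

Measured in a physicochemical assay for solubility, read by spectrophotometry, measured as kinetic solubility, at pH 8, tested at 500 uM; a lower number here means a less soluble compound, a higher number a more soluble compound:
Compound 1 `Cn1ccc2ccc(-c3cc(Nc4ccccc4S(N)(=O)=O)cc4nccnc34)cc21`: 6 ug/mL
Compound 2 `Cn1ccc2ccc(-c3cc(Nc4ccccc4S(=O)(=O)N4CCOCC4)cc4nccnc34)cc21`: 5 ug/mL

In this assay, among the compounds with values here, compound 2 stands within the scatter of compound 1, the only other compound measured. Compound 3 `Cn1ccc2ccc(-c3cc(Nc4ccccc4S(=O)(=O)NCC4CCOCC4)cc4nccnc34)cc21` has ((oxan-4-yl)methyl)amino in place of morpholin-4-yl on a sulfonyl sulfur. Within the data shown here, the one measured step at that place, a 1.2-fold lower number from compound 1 to compound 2 (0.08 log units; within the scatter), stayed within the scatter. Among the measured compounds shown here, it is the only guide here, so no change beyond the scatter is expected. The expected step is no change at the digits printed from compound 2 to compound 3 (within the scatter). Compound 3 is estimated at 5 ug/mL, with an expected range of 2 ug/mL to 12 ug/mL.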

Compound 3, solubility: 2 ug/mL
Beside the measured number, compound 3's estimate is 2.5-fold (0.40 log units) above it; the measured number falls inside the stated range.
By their numbers in this assay, from the lowest: compound 3; then compounds 2 and 1 (each within the scatter of the next).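

In this assay the group on the sulfonyl sulfur now makes a difference: ((oxan-4-yl)methyl)amino in place of morpholin-4-yl gives a 2.5-fold lower number from compound 2 to compound 3 (0.40 log units; beyond the scatter) and so moves beyond the scatter, which the step between compound 1 and compound 2 did not. Placing (oxan-4-yl)methyl on the sulfonamide nitrogen gives a 3.0-fold lower number from compound 1 to compound 3 (0.48 log units; beyond the scatter) and points the same way. Nothing available accounts for these steps. The compounds shown do not separate the hydrogen kept on the sulfonamide nitrogen from the oxan-4-yl ring and its methyl link. On these data alone, how a piperazin-1-yl group or a chain ending in a carboxylic acid would read on this sulfur remains open.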